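The source may report more compounds than this note shows. Statements on the series, on what has been measured and on what is new or still open speak of the compounds shown alone.

Measured compounds:
compound 1 `CNC(=O)c1cc(Oc2ccc(NC(=O)c3cc4cccnc4n(-c4ccc(F)cc4)c3=O)cc2)ccn1` — in a functional assay on U-87MG ATCC cells for antiproliferative activity against U-87 MG (Homo sapiens), read by MTT assay, with a stated time of 72 h (a lower number here means a stronger inhibitor, a higher number a weaker inhibitor), compound 1 gives 2910 nM
compound 2 `CCNC(=O)c1cc(Oc2ccc(NC(=O)c3cc4cccnc4n(-c4ccccc4F)c3=O)cc2)ccn1` — in this assay compound 2 gives 3250 nM
compound 3 `CCNC(=O)c1cc(Oc2ccc(NC(=O)c3cc4cccnc4n(-c4ccc(F)cc4)c3=O)cc2)ccn1` — in this assay compound 3 gives 1130 nM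

Compound 3 holds the lowest number of the three, and both of its neighbours lie beyond the scatter from it: the step of a 2.6-fold lower number from compound 1 to compound 3 (0.41 log units; beyond the scatter) and the step of a 2.9-fold lower number from compound 2 to compound 3 (0.46 log units; beyond the scatter) are each of modest size and each in the same direction.

Compound 4 `CCNC(=O)c1cc(Oc2ccc(NC(=O)c3cc4cccnc4n(-c4ccc(OC)cc4)c3=O)cc2)ccn1` is not yet measured. It differs from compound 3 in one place: methoxy in place of fluoro on an aromatic carbon, on an aromatic carbon of a six-membered aromatic ring of carbon only, para to a large group. Neither measured step bears directly on this exchange. The step to compound 3 from compound 1 changes a chain carbon on the amide-type nitrogen, and the step from compound 2 moves fluoro around the same ring rather than replacing it. No shown pair tests fluoro against methoxy. The step of a 1.3-fold higher number from compound 3 to compound 4 (0.12 log units; within the scatter) is therefore expected to stay within the scatter, with a slight lean toward a higher number for caution. Compound 4 is estimated at 1500 nM, with a range from 500 nM to 4500 nM.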

Compound 4, half-maximal inhibitory concentration: 7210 nM
Beside the measured number, compound 4's estimate is 4.8-fold (0.68 log units) below it; measured number above the stated range.
By their numbers in this assay, from the lowest: compound 3; then compounds 1 and 2 (each within the scatter of the next); then compound 4.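

In this assay, for the compounds shown here, replacing fluoro with methoxy on the aromatic carbon para to a large group gives a 6.4-fold higher number from compound 3 to compound 4 (0.80 log units; beyond the scatter), the largest single step seen so far and the first to test a change of group at this carbon. The methoxy compound also compares unfavourably with the isomeric fluoro arrangement, with a 2.2-fold higher number from compound 2 to compound 4 (0.35 log units; beyond the scatter). Of the three rings on the aromatic nitrogen, 4-fluorophenyl therefore gives the lowest number and 4-methoxyphenyl the highest, so this position responds to which group it carries as well as to where fluoro sits.

Nothing available gives a reason for this rise. The compounds shown leave open how chloro, methyl or hydroxyl on this same carbon would compare with fluoro and methoxy.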